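Chloro for Methoxy on a Chalcone-Bearing Core

The source may report more compounds than this note shows. Statements on the series, on what has been measured and on what is new or still open speak of the compounds shown alone.

Of the compounds shown here, two have been measured in a functional assay on SF-539 cells (Homo sapiens) for inhibition; a higher number here means a weaker inhibitor of growth, a lower number a stronger inhibitor of growth. Compound 1 `O=C(/C=C/c1cccc(O)c1)c1cccc(-n2cc(-c3ccc(Cl)cc3)[nH]c2=O)c1` gives 1680 nM. Compound 2 `COc1ccc(-c2cn(-c3cccc(C(=O)/C=C/c4ccc(O)c(OC)c4)c3)c(=O)[nH]2)cc1` gives 2250 nM; this is the higher of the two numbers, but compound 1 is its nearest neighbour and the gap between them lies within the scatter, so the pair cannot be ordered.

Compound 3 `COc1cc(/C=C/C(=O)c2cccc(-n3cc(-c4ccc(Cl)cc4)[nH]c3=O)c2)ccc1O` is not yet measured. It differs from compound 2 in one place: chloro in place of methoxy on an aromatic carbon. The phenol-bearing enone part of compound 2 is kept unchanged. The same chloro group is already present in compound 1, which carries a different enone part; compound 1 and compound 2 sit close together on the numbers shown.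

Among the measured compounds shown here, no measured step covers this exchange. The account expects the step from compound 2 to compound 3 to be small, a 1.3-fold lower number from compound 2 to compound 3 (0.10 log units; within the scatter), toward a slightly lower number, and not clearly beyond the scatter. In this assay compound 3 is estimated at 1800 nM, with a range from 900 nM to 3600 nM.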

Compound 3, concentration for 50% growth inhibition: 1780 nM
For compound 3 the middle estimate is 1.0-fold (0.00 log units) above the measured one, and the stated range covers the measured number.
By their numbers in this assay, from the lowest: compounds 1, 3 and 2 (each within the scatter of the next).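

In this assay the exchange of 4-methoxyphenyl for 4-chlorophenyl, read with the enone part held fixed, is a 1.3-fold lower number from compound 2 to compound 3 (0.10 log units; within the scatter) and so cannot be told apart from repeat measurements; at this place on the shared core, methoxy and chloro give numbers that cannot be ordered. The earlier pair differed in two places at once, and compound 3 now splits that comparison into single steps: with the chloro kept, 4-hydroxy-3-methoxyphenyl in place of 3-hydroxyphenyl is a 1.1-fold higher number from compound 1 to compound 3 (0.03 log units; within the scatter) and also stays within the scatter, so neither of the two changes, taken alone, separates these compounds. Nothing measured here offers an explanation for these small steps.

Since only methoxy and chloro are shown at this place, it remains open whether a bare hydrogen, an amine or a carboxylic acid there would move the number beyond the scatter. From the compounds shown here alone, on the enone side it is likewise open whether an aryl ring without any hydroxy group, or a longer chain in place of the double-bonded one, would change growth inhibition in this assay at all.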